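Lengthening an alkyl chain on a shared core

The compounds below may be only part of what the source reports. "The series", "measured", "known", "first", "only" and "open" are said of these compounds alone.

Compound 1 `Cc1nc2nc(-c3ccccc3)cc(C(F)(F)F)c2c(=O)n1Cc1cn(CCC(F)(F)C(F)(F)C(F)(F)C(F)(F)C(F)(F)C(F)(F)F)nn1` and compound 2 `CCc1nc2nc(-c3ccccc3)cc(C(F)(F)F)c2c(=O)n1Cc1cn(CCC(F)(F)C(F)(F)C(F)(F)C(F)(F)C(F)(F)C(F)(F)F)nn1` share the same core and differ only by a step that the two limits leave unreadable from compound 1 to compound 2. In a functional assay on COLO 205 cells (Homo sapiens) for cytotoxicity, read by MTT assay, with a stated time of 24 h (a lower number here means a stronger inhibitor, a higher number a weaker inhibitor), compound 1 gives > 200 ug/mL, which is a limit of the assay and not a number. In this assay compound 2 gives > 200 ug/mL, also a limit. Going by the values given here, compound 2 therefore stands at the limit of > 200 ug/mL in this assay, at which 2 of the 2 values shown sit, so its true position cannot be read, and the single measured step between compound 1 and compound 2 cannot be sized either.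

Compound 3 `CCCCCCc1nc2nc(-c3ccccc3)cc(C(F)(F)F)c2c(=O)n1Cc1cn(CCC(F)(F)C(F)(F)C(F)(F)C(F)(F)C(F)(F)C(F)(F)F)nn1` extends the chain of compound 2 by butyl in place of hydrogen on a saturated chain carbon, two bonds along the chain from an aromatic carbon. Among the compounds with values here, the only step that bears on this change is the one from compound 1 to compound 2, which the two limits leave unreadable, so there is no measured basis for a step in either direction beyond the scatter. The step that the limit leaves unreadable from compound 2 to compound 3 is accordingly expected to be small or absent, with compound 3 most likely remaining at the same limit. Compound 3 is expected to give about 300 ug/mL in this assay, within a range from 120 ug/mL to 1000 ug/mL.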

Compound 3, half-maximal inhibitory concentration: 132 ug/mL
For compound 3 the middle estimate is 2.3-fold (0.36 log units) above the measured one, and the stated range covers the measured number.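

Among the three compounds, hexyl on the shared core, on a saturated chain carbon, two bonds along the chain from an aromatic carbon, is the first chain to give a number in this assay rather than a limit. Measured against the limits of the two shorter chains, compound 3 shows an at least 1.5-fold lower number from compound 2 to compound 3 (0.18 log units; that floor lies within the scatter), and the same comparison with the methyl compound shows an at least 1.5-fold lower number from compound 1 to compound 3 (0.18 log units; that floor lies within the scatter); both sizes are only floors, so the true steps may be larger, but neither is shown to pass the scatter. Compound 1 and compound 2 both remain at a limit, and the step between them cannot be read: the limit of > 200 ug/mL in this assay, at which 2 of the 3 values shown sit.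

The compounds shown leave open whether a longer chain such as octyl or decyl would give a lower number than compound 3 or return to the limit, and whether a butyl chain at this position would already give a number. They also leave open whether a hexyl chain ending in an amine or a carboxylic acid would keep a readable number in this assay.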